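Chloro to trifluoromethoxy exchange: cytotoxicity expectations

The source may report more compounds than this note shows. Statements on the series, on what has been measured and on what is new or still open speak of the compounds shown alone.

Compound 2 `COc1cc2[nH]c(C)c(-c3ccc(Oc4ccc(Cl)cc4)cc3)c(=O)c2cc1Cl` was run in an ADME assay on HepG2 cells (Homo sapiens) for cytotoxicity, read by resazurin assay, with a stated time of 24 h; a higher number here means a weaker inhibitor, a lower number a stronger inhibitor. In this assay compound 2 gives only a limit, > 10000 nM, and no number. For the measured compounds named here, compound 1 `COc1cc2[nH]c(C)c(-c3ccc(Oc4ccc(OC(F)(F)F)c(F)c4)cc3)c(=O)c2cc1Cl` also returns only a limit in this assay, > 10000 nM. (the limit of > 10000 nM in this assay, at which 2 of the 2 values shown sit), so compound 2 stands level with the one other value shown, and no order between the two can be read. Compound 3 `COc1cc2[nH]c(C)c(-c3ccc(Oc4ccc(OC(F)(F)F)cc4)cc3)c(=O)c2cc1Cl` is not yet measured. It differs from compound 2 by trifluoromethoxy in place of chloro on an aromatic carbon. Going by the values given here, no measured step of this kind is available to lean on. Compound 1 already carries the trifluoromethoxy group that enters in compound 3, together with an extra fluorine. Compound 3 is therefore expected to remain at the limit as well, with an estimate of 15000 nM, ranging from 7000 nM to 40000 nM. The expected step that the limit leaves unreadable from compound 2 to compound 3 is none beyond the scatter.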

Compound 3, half-maximal inhibitory concentration: > 10000 nM
Compound 3: a limit, no number; the forecaster's own chance of this, stated with the estimate: 85%; the middle value is on the limit's open side.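

For the compounds shown here, compound 1, compound 2 and compound 3 all sit at a limit in this assay, and no step among them can be read: the limit of > 10000 nM in this assay, at which 3 of the 3 values shown sit. The compounds shown leave open whether trifluoromethoxy in place of chloro alters cytotoxicity beyond that limit.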